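Chloro for hydrogen on the ring beside the sulfone

This account rests on a few compounds, and the source may have more. Where it says the series, first, only, none or still open, it means among the compounds named here.

Compound 1 `O=S(=O)(/C=C\c1ncccc1F)c1ccccc1F`: 482 nM
Compound 2 `O=S(=O)(/C=C/c1ccccn1)c1cccc(F)c1`: 1680 nM

In an assay on U2OS cells for activation of nuclear factor erythroid 2-related factor 2 (Homo sapiens), read by beta-arrestin recruitment, with a stated time of 6 h (on this read-out lower numbers stand for an effect already at smaller amounts and higher numbers for an effect only at larger amounts of compound), compound 2 gives the highest of the two numbers; compound 1 gives a lower one, and the two differ by more than the scatter. Compound 3 `O=S(=O)(/C=C/c1ncccc1Cl)c1cccc(F)c1` differs from compound 2 only in one place: chloro in place of hydrogen on an aromatic carbon. Going by the values given here, no measured pair shows this exact change, so the size of the step is open. The expectation for compound 3 is a moderate move toward a lower number, as a 2.1-fold lower number from compound 2 to compound 3 (0.32 log units; beyond the scatter), because compound 1 gives 482 nM with a halogen at that carbon. Compound 3 is estimated at 800 nM, within 300 nM to 2500 nM.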

Compound 3, half-maximal effective concentration: 84 nM
Compound 3: the middle estimate sits 9.5-fold (0.98 log units) above what was measured; the whole stated range lies above it.
By their numbers in this assay, from the lowest: compound 3; then compound 1; then compound 2.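

In this assay, chloro in place of hydrogen on this aromatic carbon, two atoms from the ring nitrogen, gives a 20-fold lower number from compound 2 to compound 3 (1.30 log units; beyond the scatter). Going by these compounds alone, this is the first single change that can be read, and it shows that one added chlorine atom at this position can carry a large step. Nothing available explains why the step is so large. Going by these compounds, whether a methyl group or an amine on the same carbon would give a similar step remains open. So does whether chloro would do the same on the core of compound 1.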